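A few compounds are considered here, and "the series" means these few. Any claim that something is new, unique, unknown or untested is made for them only; others in the source may bear on it.

Measured compounds:

Compound 1 `N#Cc1ccccc1Cn1c(N2CCNCC2)cc(=O)n2nccc12` gives > 100000 nM in an ADME assay on isolated protein for inhibition of Dipeptidyl peptidase 9 (Homo sapiens), read by fluorescence, with a stated time of 10 min; on this read-out higher numbers stand for weaker inhibition and lower numbers for stronger inhibition; this is a limit of the assay and not a number.
Compound 2 `Cc1ccc(Cn2c(N3CCC[C@@H](N)C3)cc(=O)n3nccc23)cc1` gives > 100000 nM; this too is a limit.
Compound 3 `N#Cc1ccccc1Cc1c(Cl)nc2ccnn2c1N1CCC[C@@H](N)C1` gives > 100000 nM; again a limit.

So all three measured compounds sit at the same limit, and compound 1 stands nowhere apart from the other two: the limit of > 100000 nM in this assay, at which 3 of the 3 values shown sit. For the measured compounds named here, none of them shows measurable inhibition of this enzyme at the highest concentration tested, and no step between measured compounds can be read, since a limit tells only that the true value lies beyond it.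

Compound 4 `O=c1cc(N2CCNCC2)n(Cc2ccccc2)c2ccnn12` is the unmeasured partner of compound 1. The two differ in one place: hydrogen in place of cyano on an aromatic carbon. The rest of the molecule, the shared core and the piperazine, is untouched.

Going by the values given here, with every neighbour at the limit, there is no measured step to lean on for this change. The expectation is that the step from compound 1 to compound 4 in this assay is none beyond the scatter, a step that the limit leaves unreadable from compound 1 to compound 4, and that the assay again reports only a limit. Compound 4 is therefore expected to give about 150000 nM, with a range from 50000 nM to 600000 nM.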

Compound 4, half-maximal inhibitory concentration: > 100000 nM
Compound 4 ended at the assay's limit; the forecaster's own chance of this, stated with the estimate: 85%; the middle value does not contradict the limit.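

Compound 1 and compound 4 both stand at a limit of the assay and not at a number, so no step can be read for hydrogen in place of cyano in this assay: the limit of > 100000 nM in this assay, at which 4 of the 4 values shown sit.

The compounds shown leave open how strongly, if at all, any of them inhibits this enzyme, and what the 2-cyanophenyl to phenyl change does to a readable value.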